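This account rests on a few compounds, and the source may have more. Where it says the series, first, only, none or still open, it means among the compounds named here.

Compound 1 `Cn1cc(-c2cc(C(O)(C(F)(F)F)C(F)(F)F)cnc2N2CCN(S(=O)(=O)c3ccc(N)nc3)CC2)cn1` is the starting point of this account. In an ADME assay (liver) for metabolic stability, with Liver microsome (Rattus norvegicus) as the target, using microsomes and NADPH, with a stated time of 30 min, tested at 1 uM (a higher number here means faster removal of the compound, a lower number slower removal), compound 1 gives 44 mL.min-1.g-1, the lowest of the three numbers recorded. Its two companions are compound 2 `CC(C)n1cc(-c2cc(C(O)(C(F)(F)F)C(F)(F)F)cnc2N2CCN(S(=O)(=O)c3ccc(N)nc3)CC2)cn1`, which gives 198 mL.min-1.g-1, and compound 3 `CC(C)(C)n1cc(-c2cc(C(O)(C(F)(F)F)C(F)(F)F)cnc2N2CCN(S(=O)(=O)c3ccc(N)nc3)CC2)cn1`, which gives 459 mL.min-1.g-1. The measured steps all concern the group on the aromatic nitrogen of the pyrazole: a 4.5-fold higher number from compound 1 to compound 2 (0.65 log units; beyond the scatter), a 10-fold higher number from compound 1 to compound 3 (1.02 log units; beyond the scatter) and a 2.3-fold higher number from compound 2 to compound 3 (0.37 log units; beyond the scatter). Every enlargement there carried the number upward.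

Compound 4 `Nc1ccc(S(=O)(=O)N2CCN(c3ncc(C(O)(C(F)(F)F)C(F)(F)F)cc3-c3ccc4[nH]ncc4c3)CC2)cn1` has not been measured in this assay. It differs from compound 1 by 1H-indazol-5-yl in place of 1-methyl-1H-pyrazol-4-yl on an aromatic carbon. Among the compounds with values here, no measured step swaps the ring itself, so the recorded steps bear on this change only loosely; they show that a bulkier group at this place has so far raised the number, and compound 4 brings in a larger group with a donor rather than a second acceptor. A modest upward step beyond the scatter is therefore expected, a 2.0-fold higher number from compound 1 to compound 4 (0.31 log units; beyond the scatter). Compound 4 is estimated at 90 mL.min-1.g-1, within a range from 35 mL.min-1.g-1 to 230 mL.min-1.g-1.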

Compound 4, intrinsic clearance in microsomes: 88 mL.min-1.g-1
The estimate for compound 4 lay 1.0-fold (0.01 log units) above the measured number; the measured number falls inside the stated range.
By their numbers in this assay, from the lowest: compounds 1 and 4 (each within the scatter of the next); then compound 2; then compound 3.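

With 1H-indazol-5-yl on this aromatic carbon, this assay gives a 2.0-fold higher number from compound 1 to compound 4 (0.30 log units; within the scatter), so a group with more heavy atoms than 1-methyl-1H-pyrazol-4-yl is not separated from it, and the upward trend seen among the pyrazole substituents does not carry over to this ring swap. The same swap gives a 2.3-fold lower number from compound 2 to compound 4 (0.35 log units; beyond the scatter) and a 5.2-fold lower number from compound 3 to compound 4 (0.72 log units; beyond the scatter), which shows that this place can hold a fused ring with one hydrogen-bond donor while staying clear of the higher numbers of the isopropyl and tert-butyl pyrazoles. Nothing available here accounts for these differences.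

The compounds shown leave open whether the ring hydrogen of the indazole matters, which 1-methyl-1H-indazol-5-yl would test. They also leave open how a hydroxyl or an amine on the chain at the pyrazole nitrogen would compare with the plain alkyl groups.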